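The source may report more compounds than this note shows. Statements on the series, on what has been measured and on what is new or still open speak of the compounds shown alone.

Measured compounds:
Compound 1 `COc1ccc(/C=C/c2cc(OC)cc(OC)c2/C=C/C(=O)NC2CC2)cc1`: 8810 nM in a functional assay on A549 cells (Homo sapiens) for inhibition, read by MTT assay, with a stated time of 48 h; on this read-out higher numbers stand for weaker inhibition and lower numbers for stronger inhibition
Compound 2 `COc1ccc(/C=C/c2cc(OC)cc(OC)c2/C=C/C(=O)N2CCC(c3ccccc3)CC2)cc1`: 6690 nM in this assay

Compound 2 has the lower of the two numbers shown, yet its only neighbour is compound 1, and the step of a 1.3-fold lower number from compound 1 to compound 2 (0.12 log units; within the scatter) lies within the scatter, so the two cannot be set in order. That step exchanged cyclopropylamino for 4-phenylpiperidin-1-yl on a carbonyl carbon and left the read-out essentially where it was.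

Compound 3 `COc1ccc(/C=C/c2cc(OC)cc(OC)c2/C=C/C(=O)N2CCCC(C)C2)cc1` has not yet been measured. It differs from compound 2 as follows: 3-methylpiperidin-1-yl in place of 4-phenylpiperidin-1-yl on a carbonyl carbon. Among the measured compounds shown here, the only measured step that bears on this change is a 1.3-fold lower number from compound 1 to compound 2 (0.12 log units; within the scatter), which also altered the group on that carbonyl carbon and stayed within the scatter. The data give no sign that exchanging the group on the carbonyl carbon shifts the number, so for a 1.1-fold higher number from compound 2 to compound 3 (0.05 log units; within the scatter) in this assay no step beyond the scatter is expected. Compound 3 is therefore estimated at 7500 nM, with a range from 3500 nM to 16000 nM.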

Compound 3, half-maximal inhibitory concentration: 5820 nM
Beside the measured number, compound 3's estimate is 1.3-fold (0.11 log units) above it, within the range that was stated.
By their numbers in this assay, from the lowest: compounds 3, 2 and 1 (each within the scatter of the next).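

In this assay, 3-methylpiperidin-1-yl in place of 4-phenylpiperidin-1-yl on a carbonyl carbon gave a 1.1-fold lower number from compound 2 to compound 3 (0.06 log units; within the scatter), and the same group in place of cyclopropylamino gave a 1.5-fold lower number from compound 1 to compound 3 (0.18 log units; within the scatter). This adds a second and a third comparison at this place, and the one from compound 2 to compound 3 is the first to remove the six-membered aromatic ring and to go from 12 heavy atoms to 7 in the group, yet it stays within the scatter, as do the other two steps among these three amides. No evidence is available that bears on this result.

The compounds shown leave open whether any group on this carbonyl carbon can move the number beyond the scatter, for example a morpholine with its ring oxygen, a piperazine with its second ring nitrogen, or a carboxylic acid in place of the amide. They also leave open whether the core of compound 1 would respond to such exchanges in the same way on cells other than A549.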